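A few compounds are considered here, and "the series" means these few. Any claim that something is new, unique, unknown or untested is made for them only; others in the source may bear on it.

Measured so far in an ADME assay on HEK293 cells (Homo sapiens) for cytotoxicity, read by MTT assay, with a stated time of 36 h; on this read-out lower numbers stand for stronger inhibition and higher numbers for weaker inhibition:

compound 1 `O=C(c1ccc2c(c1)OCCO2)C1CCN(Cc2coc(-c3ccc(Br)cc3)n2)CC1`: compound 1 gives > 150 ug/mL, a limit of the assay.
compound 2 `O=C(c1ccc2c(c1)OCCO2)C1CCN(Cc2coc(-c3ccc(F)c(F)c3)n2)CC1`: compound 2 gives > 150 ug/mL, also a limit.
compound 3 `O=C(c1ccc2c(c1)OCCO2)C1CCN(Cc2coc(-c3cccc(F)c3)n2)CC1`: compound 3 gives > 150 ug/mL, again a limit.

Compound 1 therefore stands at a limit only, and the two further values stand at the same limit. The steps between the measured compounds are all unreadable: a step that the two limits leave unreadable from compound 1 to compound 2, a step that the two limits leave unreadable from compound 1 to compound 3 and a step that the two limits leave unreadable from compound 2 to compound 3. Going by the values given here, the only evidence on the series is the limit of > 150 ug/mL in this assay, at which 3 of the 3 values shown sit.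

Compound 4 `O=C(c1ccc2c(c1)OCCO2)C1CCN(Cc2coc(-c3ccoc3)n2)CC1` is the next compound. Among the compounds with values here, it differs from compound 1 as follows. furan-3-yl in place of 4-bromophenyl on an aromatic carbon No measured step covers an exchange of this kind, and the steps that replace the 4-bromophenyl in compound 1 by other aryl groups leave no readable size. Nothing in the series points in either direction; on the evidence of the limit of > 150 ug/mL in this assay, at which 3 of the 3 values shown sit, the expectation in this assay is a step of no readable size, with compound 4 most probably again sitting at the limit. Compound 4 is thus estimated at 150 ug/mL, within 100 ug/mL to 300 ug/mL, which means an expected step of a number no higher from compound 1 to compound 4 (the limit leaves the size open).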

Compound 4, half-maximal inhibitory concentration: > 150 ug/mL
Compound 4 was reported as a limit; the forecaster's own chance of this, stated with the estimate: 85%; the middle value sits exactly at the limit.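

In this assay, going by these compounds alone, compound 4 gives > 150 ug/mL, a limit of the assay, so no step between compound 4 and compound 1, compound 2 or compound 3 can be read. The compounds shown leave open whether any of these aryl exchanges changes cytotoxicity, with one limit as the only evidence: the limit of > 150 ug/mL in this assay, at which 4 of the 4 values shown sit.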